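The compounds below may be only part of what the source reports. "The series", "measured", "known", "first", "only" and "open" are said of these compounds alone.

Measured compounds:
compound 1, `CN1CCN(c2ccc(Nc3ncc4c(n3)N(C3CCCC3)CC(=O)N4C)cc2)CC1`, 10300 nM;
compound 2, `CN1CCN(c2ccc(Nc3ncc4c(n3)N(C3CCCC3)CC(=O)N4C)nc2)CC1`, 23700 nM;
compound 3, `CCN1C(=O)CN(C2CCCC2)c2nc(Nc3ccc(N4CCN(C)CC4)cc3)ncc21`, 26200 nM.

In a functional assay on MDA-MB-231 cells (Homo sapiens) for inhibition, read by MTT assay, with a stated time of 48 h (on this read-out lower numbers stand for stronger inhibition and higher numbers for weaker inhibition), compound 1 gives 10300 nM. Compound 3 differs from compound 1 by methyl in place of hydrogen on a saturated chain carbon bound to an amide-type nitrogen in a ring, and the step of a 2.5-fold higher number from compound 1 to compound 3 (0.41 log units; beyond the scatter). Compound 2 carries a different core; how the two cores differ is not broken down here. In this assay compound 2 gives 23700 nM, and compound 3 gives 26200 nM, the two lying within the scatter of each other.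

Compound 4, `CCN1C(=O)CN(C2CCCC2)c2nc(Nc3ccc(N4CCN(C)CC4)cn3)ncc21`, is not yet measured. It differs from compound 2 by methyl in place of hydrogen on a saturated chain carbon bound to an amide-type nitrogen in a ring, the same change as that from compound 1 to compound 3, made at the same place. Compound 4 is therefore expected to show a step of a 1.9-fold higher number from compound 2 to compound 4 (0.28 log units; within the scatter), and the range is kept wide because a 2.5-fold higher number from compound 1 to compound 3 (0.41 log units; beyond the scatter) rests on a single pair only. For compound 4 the estimate is 45000 nM, with a range from 20000 nM to 100000 nM.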

Compound 4, half-maximal inhibitory concentration: 24100 nM
The estimate for compound 4 lay 1.9-fold (0.27 log units) above the measured number, within the range that was stated.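

In this assay, methyl in place of hydrogen on a saturated chain carbon bound to an amide-type nitrogen in a ring, on the core of compound 2, gives a 1.0-fold higher number from compound 2 to compound 4 (0.01 log units; within the scatter). Set beside the same change on the core of compound 1, the two steps cannot be told apart: the same change on two cores in this assay, a 2.5-fold higher number (0.41 log units; beyond the scatter) from compound 1 to compound 3 and a 1.0-fold higher number (0.01 log units; within the scatter) from compound 2 to compound 4, 2.5-fold (0.40 log units) apart, within the scatter of two such steps

This shows no measurable difference between the two cores in how the change carries over, but with a single pair on each core it does not establish that the change carries over unaltered. The compounds shown leave open how a longer chain, such as propyl, or a chain ending in an amine or a carboxylic acid, would read at this place on either core.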